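Changing a pyridinyl group when only limits are known

The source may report more compounds than this note shows. Statements on the series, on what has been measured and on what is new or still open speak of the compounds shown alone.

compound 1 `CC(C)(C)Sc1c(CC(C)(C)C(=O)O)n(Cc2ccc(Cl)cc2)c2ccc(OCc3ccc4cccnc4n3)cc12`: > 3000 nM, a limit
compound 2 `CC(C)(C)Sc1c(CC(C)(C)C(=O)O)n(Cc2ccc(Cl)cc2)c2ccc(OCc3ccncc3)cc12`: > 3000 nM, a limit

In a functional assay (blood) for inhibition, with Homo sapiens as the target (a higher number here means a weaker inhibitor, a lower number a stronger inhibitor), compound 2 gives > 3000 nM, which is a limit and not a number. The picture so far is the limit of > 3000 nM in this assay, at which 2 of the 2 values shown sit. Compound 3 `CC(COc1ccc2c(c1)c(SC(C)(C)C)c(CC(C)(C)C(=O)O)n2Cc1ccc(Cl)cc1)c1ccccn1` differs from compound 2 in one place: 1-(pyridin-2-yl)ethyl in place of pyridin-4-yl on a saturated chain carbon bound to an oxygen on an aromatic ring. Going by the values given here, the only measured step, a step that the two limits leave unreadable from compound 1 to compound 2, changed the group at this same place, but it gives no size to carry over. No step beyond the scatter is expected in this assay, and no direction can be given. The expected change is a number no higher from compound 2 to compound 3 (the limit leaves the size open). Compound 3 is expected at 3000 nM, with an estimated range of 1000 nM to 9000 nM.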

Compound 3, half-maximal inhibitory concentration: 270 nM
Beside the measured number, compound 3's estimate is 11-fold (1.05 log units) above it, and the stated range ends above it.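

In this assay, the group at this place, on a saturated chain carbon bound to an oxygen on an aromatic ring, can move the result: 1-(pyridin-2-yl)ethyl brings an at least 11-fold lower number from compound 2 to compound 3 (1.04 log units; beyond the scatter), and also an at least 11-fold lower number from compound 1 to compound 3 (1.04 log units; beyond the scatter). The step from compound 1 to compound 2 cannot be read, as both values are limits. Compound 3 thus gives the first readable number here, while the others remain limits: the limit of > 3000 nM in this assay, at which 2 of the 3 values shown sit.

The change alters both the pyridine attachment and the chain, and the compounds shown do not separate the two. On these data alone, how a longer chain such as 1-(pyridin-2-yl)propyl or a ring without nitrogen such as 1-phenylethyl would read remains open.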